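Selenocyanate on the chain of compound 1

This account rests on a few compounds, and the source may have more. Where it says the series, first, only, none or still open, it means among the compounds named here.

Compound 1 `COc1ccc(N(C)c2nc(C)nc3ccccc23)cc1OCCN` stands weakest of the three measured compounds: in a functional assay on MDA-MB-231 cells (Homo sapiens) for inhibition, read by MTT assay, with a stated time of 48 h (on this read-out lower numbers stand for stronger inhibition and higher numbers for weaker inhibition), compound 1 gives 682 nM. Compound 2 `Cc1nc(N(C)c2ccc([Se]C#N)c(F)c2)c2ccccc2n1` carries selenium on an aromatic ring and gives 6 nM in this assay; compound 3 `C[Se]c1ccc(N(C)c2nc(C)nc3ccccc23)cc1Cl` also carries selenium on an aromatic ring and gives 7 nM, both gaps from compound 1 lying beyond the scatter. Compound 4 `COc1ccc(N(C)c2nc(C)nc3ccccc23)cc1OCCCC[Se]C#N` differs from compound 1 by a group of 5 heavy atoms (3 carbon, 1 nitrogen, 1 selenium; no ring) in place of one nitrogen atom, on a saturated chain carbon, two bonds along the chain from an oxygen on an aromatic ring. Among the compounds with values here, no measured pair shares this change, and no measured compound carries selenium on a saturated chain. A move toward stronger inhibition of a 4.5-fold lower number from compound 1 to compound 4 (0.66 log units; beyond the scatter) is expected, beyond the scatter, because compound 2 gives 6 nM and compound 3 gives 7 nM. For compound 4 the estimate in this assay is 150 nM, range 30 nM to 700 nM.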

Compound 4, half-maximal inhibitory concentration: 1350 nM
Compound 4: the middle estimate sits 9.0-fold (0.95 log units) below what was measured; measured number above the stated range.
By their numbers in this assay, from the lowest: compounds 2 and 3 (each within the scatter of the next); then compounds 1 and 4 (each within the scatter of the next).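

In this assay, the step at this saturated chain carbon is a 2.0-fold higher number from compound 1 to compound 4 (0.30 log units; within the scatter), so the amino group and the group of 5 heavy atoms that replaces it cannot be told apart on this read-out. Selenium on a saturated chain is now represented, and at this position the exchange leaves the number within the scatter. Nothing available bears on why this is so.

Still open, as far as these compounds go, is whether a carboxylic acid or a plain nitrile at this chain end, or a shorter chain carrying the same selenium group, would give a step beyond the scatter.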